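Urea series: replacing the 4-bromo-1H-indazol-1-yl group

The source may report more compounds than this note shows. Statements on the series, on what has been measured and on what is new or still open speak of the compounds shown alone.

Measured compounds, read in a functional assay on SGC-7901 cells (Homo sapiens) for cytotoxicity, read by MTT assay, with a stated time of 72 h; on this read-out higher numbers stand for weaker inhibition and lower numbers for stronger inhibition:
compound 1 `O=C(Nc1ccc(-n2ncc3c(Br)cccc32)cc1)Nc1ccc(Cl)c(C(F)(F)F)c1`: 16600 nM
compound 2 `Cc1cccc2c1cnn2-c1ccc(NC(=O)Nc2ccc(Cl)c(C(F)(F)F)c2)cc1`: 14200 nM
compound 3 `O=C(Nc1ccc(-n2ncc3c(C(F)(F)F)cccc32)cc1)Nc1ccc(C(F)(F)F)cc1`: 4000 nM

On these numbers compound 1 stands with the highest figure of the three. Its nearest neighbour is compound 2, which differs only in a methyl in place of the bromo on an aromatic carbon, and that step, a 1.2-fold lower number from compound 1 to compound 2 (0.07 log units; within the scatter), lies within the scatter. Going by the values given here, compound 3 is the furthest from compound 1; the two differ in more than one place and no single step is drawn between them, so only the two values themselves can be set side by side.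

Compound 4 `O=C(Nc1ccc(-n2ncc3cccnc32)cc1)Nc1ccc(Cl)c(C(F)(F)F)c1` has not been measured. It differs from compound 1 in one place: a group of 9 heavy atoms (6 carbon, 3 nitrogen; one five-membered aromatic ring with 2 hetero atoms, one six-membered aromatic ring with 1 hetero atom) in place of a group of 10 heavy atoms (7 carbon, 2 nitrogen, 1 bromine; one five-membered aromatic ring with 2 hetero atoms, one six-membered aromatic ring of carbon only), on an aromatic carbon. Among the compounds with values here, no measured step alters this part of the molecule in the same way. Within the data shown here, the only step that touches the same group is the one from compound 1 to compound 2, which was within the scatter, so the guide is weak. The expectation is for no step beyond the scatter in this assay, with a wide range to cover the change of group. The estimated step from compound 1 to compound 4 is a 1.2-fold higher number from compound 1 to compound 4 (0.08 log units; within the scatter). Compound 4 is estimated at 20000 nM, expected to fall between 7000 nM and 60000 nM.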

Compound 4, half-maximal inhibitory concentration: > 32000 nM
Compound 4: only a limit was reported; the forecaster's own chance of this, stated with the estimate: 15%; middle value at least 1.6-fold (0.20 log units) away from the limit.
By their numbers in this assay, from the lowest: compound 3; then compounds 2 and 1 (each within the scatter of the next). At a limit, above all of these: compound 4.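

In this assay compound 4 is reported only as a limit: the limit of > 32000 nM in this assay, at which 1 of the 4 values shown sits.

Read against compound 2, the change of group gives an at least 2.2-fold higher number from compound 2 to compound 4 (0.35 log units; beyond the scatter), the first step at this part of the molecule that clears the scatter, whereas the exchange of bromo for methyl gave a 1.2-fold lower number from compound 1 to compound 2 (0.07 log units; within the scatter). Read against compound 1, the same change gives an at least 1.9-fold higher number from compound 1 to compound 4 (0.28 log units; that floor lies within the scatter), so the limit alone does not separate compound 4 from compound 1, and only the comparison with compound 2 shows that this place responds to a change of group at all.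

The compounds shown leave open how far compound 4 lies past its limit, and whether the hetero atom in the six-membered aromatic ring or the absence of the bromo or methyl group carries the difference, as both change together in these steps. Also open, as far as these compounds go, is how an amine, a methoxy group or a carboxylic acid on this aromatic carbon would read, with the rest of compound 1 held constant.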